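The source may hold more compounds than are shown below. What is called first, only, known or untested is meant among the compounds shown, and "the series" means these compounds.

Measured compounds:
compound 1, `CNc1nc(-c2ccccc2)nc2c1nnn2Cc1ccccc1F`, 25 nM
compound 2, `CCCNc1nc(-c2ccccc2)nc2c1nnn2Cc1ccccc1F`, 3.2 nM
compound 3, `CCCCNc1nc(-c2ccccc2)nc2c1nnn2Cc1ccccc1`, 11 nM

The three measured compounds were examined in an assay on Cerebral cortex for displacement of a labelled ligand from adenosine receptor A1 (Bos taurus); on this read-out lower numbers stand for stronger inhibition and higher numbers for weaker inhibition. Going by the values given here, compound 1 and compound 2 share one core; the only change between them is ethyl in place of hydrogen on a saturated chain carbon bound to a nitrogen on an aromatic ring, and in this assay that change gave a 7.8-fold lower number from compound 1 to compound 2 (0.89 log units; beyond the scatter). Compound 3 carries a different core, and how the two cores differ is not broken down here; in this assay compound 3 sits between the other two, giving a higher number than compound 2 and a lower one than compound 1.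

Compound 4, `CCCCCCNc1nc(-c2ccccc2)nc2c1nnn2Cc1ccccc1`, has not yet been measured. It differs from compound 3 by ethyl in place of hydrogen on a saturated chain carbon, four bonds along the chain from a nitrogen on an aromatic ring. Among the compounds with values here, this is the same kind of change as the one from compound 1 to compound 2, but not the same: there the ethyl entered on a saturated chain carbon bound to a nitrogen on an aromatic ring, whereas here it enters on a saturated chain carbon four bonds along the chain from a nitrogen on an aromatic ring, so the chain grows further from the ring.

Within the data shown here, because the earlier lengthening gave a 7.8-fold lower number from compound 1 to compound 2 (0.89 log units; beyond the scatter), a gain of the same kind is possible, yet the chain on compound 3 is already longer, and only two measured pairs exist, so the expectation is cautious. From compound 3 to compound 4 the estimated step is a 1.2-fold lower number from compound 3 to compound 4 (0.09 log units; within the scatter). Compound 4 is expected to give about 9 nM, most likely between 2.5 nM and 35 nM.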

Compound 4, inhibition constant: 13.2 nM
The estimate for compound 4 lay 1.5-fold (0.17 log units) below the measured number, and the stated range covers the measured number.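

In this assay, placing ethyl on a saturated chain carbon, four bonds along the chain from a nitrogen on an aromatic ring, gave a 1.2-fold higher number from compound 3 to compound 4 (0.08 log units; within the scatter), so this lengthening brought no gain that can be read from the data. Set beside the earlier lengthening, the same kind of change did not carry over from one core to the other with the same size: the same change on two cores in this assay, a 7.8-fold lower number (0.89 log units; beyond the scatter) from compound 1 to compound 2 and a 1.2-fold higher number (0.08 log units; within the scatter) from compound 3 to compound 4, 9.4-fold (0.97 log units) apart, beyond the scatter of two such steps This does not show that the core alone sets the outcome, since the two steps differ both in their core and in where the ethyl enters the chain, and one pair on each core gives no general rule for the series.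

The compounds shown leave open how a butyl chain would read on the core of compound 2, and how a propyl chain would read on the core of compound 3, either of which would set the two cores side by side with the same chain. On these data alone, whether a longer chain, or a chain carrying an amine or a carboxylic acid, would shift the number in this assay also stays open.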